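Swapping the aryl group on the urea of a quinazoline-type series

A few compounds are considered here, and "the series" means these few. Any claim that something is new, unique, unknown or untested is made for them only; others in the source may bear on it.

Of the compounds shown here, three sharing one core have been measured in a functional assay on RT-112 cells (Homo sapiens) for antiproliferative activity, read by MTT assay, with a stated time of 72 h; on this read-out higher numbers stand for weaker inhibition of growth and lower numbers for stronger inhibition of growth. Compound 1 `COc1cc(NC(=O)Nc2cccc3c(Nc4cc(OC)cc(OC)c4)ncnc23)cc(OC)c1` gives 366 nM, compound 2 `COc1cc(Nc2ncnc3c(NC(=O)Nc4ccc(C)c(C)c4)cccc23)cc(OC)c1` gives 8.8 nM, and compound 3 `COc1cc(Nc2ncnc3c(NC(=O)Nc4cccc(Cl)c4Cl)cccc23)cc(OC)c1` gives 63.2 nM. Compound 2 has the lowest number of the three: compound 3 is nearest, compound 1 furthest. Compound 4 `COc1cc(Nc2ncnc3c(NC(=O)Nc4ccc5c(c4)OCCO5)cccc23)cc(OC)c1` differs from compound 2 by 2,3-dihydro-1,4-benzodioxin-6-yl in place of 3,4-dimethylphenyl on an amide-type nitrogen. Within the data shown here, two measured steps touch this position: a 42-fold lower number from compound 1 to compound 2 (1.62 log units; beyond the scatter) and a 7.2-fold higher number from compound 2 to compound 3 (0.86 log units; beyond the scatter). Both show that any change away from the 3,4-dimethylphenyl of compound 2 has so far raised the number, and the oxygen-bearing ring of compound 1 raised it most. A modest rise is therefore expected, a 6.8-fold higher number from compound 2 to compound 4 (0.83 log units; beyond the scatter). Compound 4 is estimated at 60 nM, with a range from 15 nM to 250 nM.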

Compound 4, concentration for 50% growth inhibition: 2750 nM
Beside the measured number, compound 4's estimate is 46-fold (1.66 log units) below it; measured number outside the range, above it.
By their numbers in this assay, from the lowest: compound 2; then compound 3; then compound 1; then compound 4.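

In this assay the 2,3-dihydro-1,4-benzodioxin-6-yl group gives the weakest growth inhibition of the four compounds, with a 310-fold higher number from compound 2 to compound 4 (2.49 log units; beyond the scatter) and a 44-fold higher number from compound 3 to compound 4 (1.64 log units; beyond the scatter) and a 7.5-fold higher number from compound 1 to compound 4 (0.88 log units; beyond the scatter). Among these compounds, this position therefore tolerates change far less than the earlier compounds suggested, and the two aryl groups carrying oxygen, in compound 1 and compound 4, now give the two highest numbers, a link resting on just those two compounds. Nothing measured here explains the loss. Still open, going by these compounds, is whether a ring without oxygen, such as indanyl, would keep the low number of compound 2, and how an unsubstituted phenyl would compare.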